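Swapping Pyridinyl Rings in a Cytotoxicity Series

This account rests on a few compounds, and the source may have more. Where it says the series, first, only, none or still open, it means among the compounds named here.

Measured in an ADME assay on L02 cells (Homo sapiens) for cytotoxicity, read by MTT assay, with a stated time of 24 h; a lower number here means a stronger inhibitor, a higher number a weaker inhibitor:
Compound 1, `COc1cc(/C=C2\CN(C)C/C(=C\c3cccnc3)C2=O)cc(OC)c1OC`: 14400 nM
Compound 2, `COc1ccc(/C=C2\CN(C)C/C(=C\c3cccnc3)C2=O)c(OC)c1OC`: 13600 nM
Compound 3, `COc1cc(/C=C2\CN(C)C/C(=C\c3ccncc3)C2=O)cc(OC)c1OC`: 16400 nM

All three numbers lie within the scatter of one another, so none can be called the stronger or weaker inhibitor. Compound 3 differs from compound 1 by pyridin-4-yl in place of pyridin-3-yl on a double-bonded chain carbon bound to a double-bonded ring carbon, and that change gave a 1.1-fold higher number from compound 1 to compound 3 (0.06 log units; within the scatter). Compound 2 and compound 1 have the same atoms joined differently; the difference between the two cores is not broken down here.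

Compound 4, `COc1ccc(/C=C2\CN(C)C/C(=C\c3ccncc3)C2=O)c(OC)c1OC`, is not yet measured. It differs from compound 2 by pyridin-4-yl in place of pyridin-3-yl on a double-bonded chain carbon bound to a double-bonded ring carbon, the same change, at the same place, as from compound 1 to compound 3. Because a 1.1-fold higher number from compound 1 to compound 3 (0.06 log units; within the scatter) stayed within the scatter, the step from compound 2 to compound 4 is expected to be a 1.1-fold higher number from compound 2 to compound 4 (0.04 log units; within the scatter). Compound 4 is therefore estimated at 15000 nM in this assay, expected to fall between 8000 nM and 30000 nM.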

Compound 4, half-maximal inhibitory concentration: 15600 nM
Compound 4: the middle estimate sits 1.0-fold (0.02 log units) below what was measured; the range from low to high includes it.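

In this assay, pyridin-4-yl in place of pyridin-3-yl on the core of compound 2 gave a 1.1-fold higher number from compound 2 to compound 4 (0.06 log units; within the scatter). Set beside the earlier step, the change carries from one core to the other with no difference that can be told apart: the same change on two cores in this assay, a 1.1-fold higher number (0.06 log units; within the scatter) from compound 1 to compound 3 and a 1.1-fold higher number (0.06 log units; within the scatter) from compound 2 to compound 4, 1.0-fold (0.00 log units) apart, within the scatter of two such steps

This is agreement between two steps that both stay within the scatter, so it shows that the swap has no effect large enough to read on either core, and it says nothing about other cores or other assays.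

The compounds shown leave open how a plain phenyl, a pyridin-2-yl or a pyridine ring carrying an amine would read in this assay at this place. As far as these compounds go, whether any group here can move the number beyond the scatter also remains open.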